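The source may hold more compounds than are shown below. What is called first, only, known or untested is meant among the compounds shown, and "the series" means these compounds.

Measured so far in the series:

compound 1, `O=c1oc2ccc(F)cc2c(=O)n1-c1ccc(Br)cc1F`, 7200 nM
compound 2, `O=c1oc2ccc(F)cc2c(=O)n1-c1ccc(I)cc1F`, 6000 nM
compound 3, `O=c1oc2ccc(Br)cc2c(=O)n1-c1ccc(Cl)cc1F`, 7500 nM

All three numbers come from an ADME assay on RAW264.7 cells (Mus musculus) for cytotoxicity, read by MTT assay, with a stated time of 24 h; a higher number here means that more compound is tolerated, a lower number that less compound is tolerated. Compound 1 and compound 2 share a core and differ in one place only, (iodo in place of bromo on an aromatic carbon). This change gave a 1.2-fold lower number from compound 1 to compound 2 (0.08 log units; within the scatter). Compound 3 stands on a different core; the difference between the two cores is not broken down here. Its value sits close to the other two: against compound 1 and against compound 2 the gaps are within the scatter, so no order among the three can be read from the data.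

Compound 4, `O=c1oc2ccc(I)cc2c(=O)n1-c1ccc(Cl)cc1F`, has not yet been measured in this assay. It differs from compound 3 in one place, (iodo in place of bromo on an aromatic carbon). For the measured compounds named here, this is the same kind of change as the one from compound 1 to compound 2, but not the same: in compound 4 the place is on an aromatic carbon of a six-membered aromatic ring of carbon only, part of a fused or bridged system of two rings, meta to a fused ring and para to a fused ring, whereas in compound 2 it is meta to a fluoro group and para to a large group.

The step from compound 3 to compound 4 in this assay is estimated at a 1.2-fold lower number from compound 3 to compound 4 (0.06 log units; within the scatter), since the earlier 1.2-fold lower number from compound 1 to compound 2 (0.08 log units; within the scatter) was within the scatter. This expectation rests on compound 3 giving 7500 nM. Compound 4 is therefore expected at 6500 nM, estimated between 3500 nM and 12000 nM.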

Compound 4, half-maximal cytotoxic concentration: 8900 nM
For compound 4 the middle estimate is 1.4-fold (0.14 log units) below the measured one, within the range that was stated.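

In this assay, iodo in place of bromo on an aromatic carbon of the fused system gives a 1.2-fold higher number from compound 3 to compound 4 (0.07 log units; within the scatter). Set beside the same kind of change at the other place, the two steps do not differ: the same change on two cores in this assay, a 1.2-fold lower number (0.08 log units; within the scatter) from compound 1 to compound 2 and a 1.2-fold higher number (0.07 log units; within the scatter) from compound 3 to compound 4, 1.4-fold (0.15 log units) apart, within the scatter of two such steps. Within this pair of cores, the change can therefore be carried from one core to the other with the expectation of a step inside the scatter, and the opposite directions of the two steps carry no meaning; this does not show that the two places respond identically, since any difference smaller than the scatter would stay hidden, and two small steps say nothing about the same change on any further core.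

All the compounds shown vary only among fluoro, chloro, bromo and iodo groups, so it stays open whether an amine, a carboxylic acid or a methoxy group at these places would move the number beyond the scatter. Also open, as far as these compounds go, is what a plain aromatic hydrogen in place of the bromo or iodo group would give, which would show whether a halogen at that place matters at all in this assay.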